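This account rests on a few compounds, and the source may have more. Where it says the series, first, only, none or still open, it means among the compounds named here.

Measured in a functional assay on A549 cells (Homo sapiens) for cytotoxicity, read by MTT assay, with a stated time of 48 h; a higher number here means a weaker inhibitor, a lower number a stronger inhibitor:
Compound 1 `COc1c(OCCCCN2CCNCC2)cc(O)c2c(=O)cc(-c3ccccc3)oc12`: 1740 nM
Compound 2 `COc1c(OCc2nc3ccccc3[nH]2)cc(O)c2c(=O)cc(-c3ccccc3)oc12`: > 100000 nM, a limit of the assay and not a number
Compound 3 `COc1c(OCCCN2CCCC2)cc(O)c2c(=O)cc(-c3ccccc3)oc12`: 1390 nM

For the measured compounds named here, only two of these values are true numbers, and they sit close together: a 1.3-fold lower number from compound 1 to compound 3 (0.10 log units; within the scatter). Compound 4 `COc1c(OCCCCN2CCN(C)CC2)cc(O)c2c(=O)cc(-c3ccccc3)oc12`, not yet measured, carries (4-methylpiperazin-1-yl)methyl in place of pyrrolidin-1-yl, on a saturated chain carbon, three bonds along the chain from an oxygen on an aromatic ring ((4-methylpiperazin-1-yl)methyl in place of pyrrolidin-1-yl on a saturated chain carbon, three bonds along the chain from an oxygen on an aromatic ring). The small step just given swaps pyrrolidin-1-yl for a related piperazine group at that same place, so it is the closest guide. The large step of an at least 71-fold lower number from compound 2 to compound 3 (1.85 log units; beyond the scatter) involves 1H-benzimidazol-2-yl, a group absent from this change, so it bears little on it. No step beyond the scatter is therefore expected in this assay. The expected step is a 1.1-fold higher number from compound 3 to compound 4 (0.03 log units; within the scatter). For compound 4 the estimate is 1500 nM, with an expected range of 550 nM to 4500 nM.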

Compound 4, half-maximal inhibitory concentration: 1500 nM
The estimate for compound 4 equals the measured number at the digits printed; the measured number falls inside the stated range.
By their numbers in this assay, from the lowest: compounds 3, 4 and 1 (each within the scatter of the next). At a limit, above all of these: compound 2.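

In this assay, adding a methyl on the ring amine nitrogen makes no measurable difference (a 1.2-fold lower number from compound 1 to compound 4 (0.06 log units; within the scatter)), and neither does the change from pyrrolidin-1-yl to the larger (4-methylpiperazin-1-yl)methyl (a 1.1-fold higher number from compound 3 to compound 4 (0.03 log units; within the scatter)). At this place on the chain, all three amine ends therefore read alike. Compound 2 sits at a limit of the assay, not a number, so its gap is only a bound (an at least 66-fold lower number from compound 2 to compound 4 (1.82 log units; beyond the scatter)).

On these data alone, whether a morpholine ring or an open-chain dimethylamine would read the same remains open. So does the effect of a shorter chain carrying the same amines.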